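A methyl removed from compound 3

The compounds below may be only part of what the source reports. "The series", "measured", "known", "first", "only" and "open" are said of these compounds alone.

- compound 1 `N=c1c2c(-c3ccccc3)c(-c3ccccc3)n(Cc3ccccc3)c2ncn1CCNc1ccncc1` gives 6590 nM; 6610 nM (2 entries) in a functional assay on PC-3M cells (Homo sapiens) for antiproliferative activity, read by microscopy, with a stated time of 24 h; a higher number here means a weaker inhibitor, a lower number a stronger inhibitor
- compound 2 `COc1ccc(-c2c(-c3ccc(OC)cc3)n(Cc3ccccc3)c3ncn(CCCO)c(=N)c23)cc1` gives > 20000 nM as a limit
- compound 3 `COc1ccc(-c2c(-c3ccc(OC)cc3)n(Cc3ccccc3)c3ncn([C@H]4CC[C@H](OC)CC4)c(=N)c23)cc1` gives > 20000 nM as a limit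

Compound 3 has no number in this assay and stands only at a limit, as does most of this small set (the limit of > 20000 nM in this assay, at which 2 of the 3 values shown sit). Compound 4 `COc1ccc(-c2c(-c3ccc(OC)cc3)n(Cc3ccccc3)c3ncn([C@H]4CC[C@H](O)CC4)c(=N)c23)cc1` has hydrogen in place of methyl on an oxygen on a saturated carbon, which turns 4-methoxycyclohexyl into 4-hydroxycyclohexyl (hydrogen in place of methyl on an oxygen on a saturated carbon).

Among the compounds with values here, the one measured step that bears on this, a step that the two limits leave unreadable from compound 2 to compound 3, has no readable size. Compound 2, with its 3-hydroxypropyl, reads > 20000 nM as a limit. Only compound 1 gives real numbers (the several entries of compound 1 in this assay, 6590 nM; 6610 nM (2 entries)), but it differs from the others in several places, so it sets no size for this change.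

No step beyond the scatter is therefore expected, and the estimated step of a number no higher from compound 3 to compound 4 (the limit leaves the size open) should be read in that light. Another limit is quite likely. The estimate for compound 4 is 20000 nM (8000 nM to 30000 nM).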

Compound 4, half-maximal inhibitory concentration: > 20000 nM
Compound 4: no number, only a limit; the forecaster's own chance of this, stated with the estimate: 70%; the middle value lies on the limit itself.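

In this assay compound 4 gives > 20000 nM, which is a limit and not a number. Within the data shown here, compound 2 and compound 3 also stand only at limits, so no step among the three can be read. As far as these compounds go, what stays open is what real values lie behind these limits, and so whether hydroxy in place of methoxy matters at all.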